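This account rests on a few compounds, and the source may have more. Where it says the series, first, only, none or still open, it means among the compounds named here.

Measured compounds:
compound 1 `Cc1ccc(Oc2ccc(CC3SC(=O)NC3=O)cc2)cc1C` — 727 nM
compound 2 `O=C1NC(=O)C(Cc2ccc(Oc3ccccc3Cl)cc2)S1` — 1190 nM

Both compounds share a core and differ only in the aryl group attached through the ether oxygen. In a functional assay for agonist activity at Free fatty acid receptor 1 (Homo sapiens), read by FLIPR, in the presence of a further agent that is not named here (a lower number here means that less compound is needed, a higher number that more compound is needed for the effect), compound 1 gives 727 nM, and in the same test compound 2 gives 1190 nM. The gap between these two numbers lies within the scatter of repeated measurements, so the two compounds cannot be told apart on the numbers shown; neither can be called the more or less active one. A newcomer should read this as two compounds of essentially the same potency.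

Compound 3 `Cc1cccc(Oc2ccc(CC3SC(=O)NC3=O)cc2)c1` has not yet been measured. It differs from compound 2 in one place: 3-methylphenyl in place of 2-chlorophenyl on an oxygen on an aromatic ring. Going by the values given here, no measured pair shows this exact exchange, so the expectation rests on how little the two aryl variants seen so far differ from each other.

Compound 3 is expected to give 900 nM in this assay, with a range of 350 nM to 2300 nM. The step from compound 2 is estimated as a 1.3-fold lower number from compound 2 to compound 3 (0.12 log units; within the scatter), that is, no change beyond the scatter.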

Compound 3, half-maximal effective concentration: 203 nM
For compound 3 the middle estimate is 4.4-fold (0.65 log units) above the measured one; measured number outside the range, below it.
By their numbers in this assay, from the lowest: compound 3; then compounds 1 and 2 (each within the scatter of the next).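

Compound 1 and compound 2 could not be told apart in this assay, which gave no sign that the aryl group on the ether oxygen affects the number. Compound 3 changes that picture: 3-methylphenyl in place of 2-chlorophenyl gives a 5.9-fold lower number from compound 2 to compound 3 (0.77 log units; beyond the scatter) and thus a real difference, so this position does respond to the group it carries. The second step is smaller in its structural change, since only hydrogen in place of methyl on an aromatic carbon separates the two compounds, yet it gives a 3.6-fold lower number from compound 1 to compound 3 (0.55 log units; beyond the scatter) and also lies beyond the scatter, so an edit of a single methyl on this ring is enough to move the number, and here the lower number belongs to compound 3, the one without that extra methyl.

Still open, as far as these compounds go, is whether the step from compound 2 comes from the change of atom or from its place on the ring, a question that 2-methylphenyl and 3-chlorophenyl would separate, and how a methoxy group or an amine in place of the methyl would read. Nothing measured here explains why these changes have the size they do.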